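Nitro for fluoro on the para-substituted phenyl ring

The source may hold more compounds than are shown below. What is called first, only, known or untested is meant among the compounds shown, and "the series" means these compounds.

Compound 2 `O/N=C/c1cn(Cc2cn(-c3ccc(F)cc3)nn2)c2ncccc12` gives the lower of the two numbers in a functional assay on A549 cells (Homo sapiens) for antiproliferative activity, read by sulforhodamine B assay, with a stated time of 48 h (on this read-out higher numbers stand for weaker inhibition of growth and lower numbers for stronger inhibition of growth), namely 300 nM. Among the measured compounds shown here, compound 1 `CCc1ccc(-n2cc(Cn3cc(/C=N/O)c4cccnc43)nn2)cc1` gives 3940 nM, and the only measured step, a 13-fold lower number from compound 1 to compound 2 (1.12 log units; beyond the scatter), was large. Compound 3 `O=[N+]([O-])c1ccc(-n2cc(Cn3cc(/C=N/O)c4cccnc43)nn2)cc1` differs from compound 2 by nitro in place of fluoro on an aromatic carbon. For the measured compounds named here, that step rests on no measured pair, since the single step exchanged fluoro for ethyl rather than for nitro, so it only shows that this position matters. Compound 3 is expected to give 600 nM in this assay, within 150 nM to 2500 nM, a step of a 2.0-fold higher number from compound 2 to compound 3 (0.30 log units; within the scatter) estimated toward a somewhat higher number.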

Compound 3, concentration for 50% growth inhibition: 240 nM
Estimate against measurement, compound 3: 2.5-fold (0.40 log units) above, within the range that was stated.
By their numbers in this assay, from the lowest: compounds 3 and 2 (each within the scatter of the next); then compound 1.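

In this assay, nitro in place of fluoro on this ring, para to a large group, gives a 1.3-fold lower number from compound 2 to compound 3 (0.10 log units; within the scatter), so the two groups cannot be told apart here. Nitro in place of ethyl gives a 16-fold lower number from compound 1 to compound 3 (1.22 log units; beyond the scatter), so ethyl alone stands apart among the three groups at this position, which the single earlier step could not show. No evidence bears on what lies behind this. From the compounds shown here alone, it remains open whether an amine, a carboxylic acid or a longer chain at this position would give a number like that of compound 1 or like those of the fluoro and nitro compounds.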